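This account rests on a few compounds, and the source may have more. Where it says the series, first, only, none or still open, it means among the compounds named here.

Three related compounds have so far been measured in a functional assay on NCI-H460 cells (Homo sapiens); a higher number here means that more compound is needed for the effect, a lower number that less compound is needed. Compound 1 `COc1cc(C2OC(c3ccc(N)c(C)c3)=NN2C(C)=O)cc(OC)c1OC` gives 0.059 uM, compound 2 `COc1ccc(C2OC(c3ccc(N(C)C)cc3)=NN2C(C)=O)c(OC)c1OC` gives 6.8 uM, and compound 3 `COc1cc(C2OC(c3ccc(N(C)C)cc3)=NN2C=O)cc(OC)c1OC` gives 0.12 uM. Compound 3 therefore holds the middle place: its number is higher than that of compound 1, by a margin just beyond the usual scatter, and far lower than that of compound 2.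

Compound 4 `COc1cc(C2OC(c3ccc(N(C)C)cc3)=NN2C(=O)CN=[N+]=[N-])cc(OC)c1OC` keeps all of compound 3 except for one change, azidomethyl in place of hydrogen on a carbonyl carbon, (azidomethyl in place of hydrogen on a carbonyl carbon). In other words, formyl becomes (azidomethyl)carbonyl.

For the measured compounds named here, no measured pair isolates this change, so the forecast is uncertain. Compound 1 and compound 2 also carry a carbon group rather than hydrogen on that carbonyl carbon, but they differ from compound 3 elsewhere too. Their numbers lie far apart, with compound 1 at 0.059 uM and compound 2 at 6.8 uM, so a larger group there need not bring a high number.

In this assay a small rise is expected, close to the edge of the scatter, with an estimated step of a 2.1-fold higher number from compound 3 to compound 4 (0.32 log units; beyond the scatter). The estimate for compound 4 is 0.25 uM, with an expected range from 0.05 uM to 1.5 uM.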

Compound 4, concentration for half-maximal effect: 0.53 uM
Beside the measured number, compound 4's estimate is 2.1-fold (0.33 log units) below it; low and high end bracket the measured number.
By their numbers in this assay, from the lowest: compound 1; then compound 3; then compound 4; then compound 2.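

For the compounds shown here, this is the first pair in the set that differs in one place only, so the carbonyl carbon can now be read on its own: in this assay, azidomethyl in place of hydrogen gives a 4.4-fold higher number from compound 3 to compound 4 (0.65 log units; beyond the scatter). The step is modest but beyond the scatter, which shows that this change costs some potency without abolishing the effect, as compound 4 still gives 0.53 uM in this assay. No measurement at hand bears on what lies behind this rise.

A single step cannot show whether the rise belongs to azidomethyl in particular or would follow from any carbon group in place of hydrogen at this position. Aminomethyl, hydroxymethyl or a longer chain such as azidoethyl on that carbonyl carbon, each set on the core of compound 3, would help separate these two readings and show how much room the position leaves.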